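From 2-chlorophenyl to 3-chlorophenyl on a shared core

The source may hold more compounds than are shown below. What is called first, only, known or untested is meant among the compounds shown, and "the series" means these compounds.

Of the compounds shown here, three with a shared core have numbers so far. Compound 1 `NS(=O)(=O)c1ccc(N2N=C(c3ccc(Oc4ccccc4)cc3)CC2c2ccccc2)cc1` reads 42000 nM in an ADME assay on MT4 cells (Homo sapiens) for cytotoxicity, read by MTT assay, with a stated time of 96 h (a lower number here means that less compound is tolerated, a higher number that more compound is tolerated), and compound 2 `Cc1cccc(C2CC(c3ccc(Oc4ccccc4)cc3)=NN2c2ccc(S(N)(=O)=O)cc2)c1` reads 35000 nM on the same measure. Compound 3 `NS(=O)(=O)c1ccc(N2N=C(c3ccc(Oc4ccccc4)cc3)CC2c2ccccc2Cl)cc1` reads 40000 nM and so sits with both of them, since its steps to each lie within the scatter.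

Compound 4 `NS(=O)(=O)c1ccc(N2N=C(c3ccc(Oc4ccccc4)cc3)CC2c2cccc(Cl)c2)cc1` has not yet been measured. In it, 3-chlorophenyl stands in place of 2-chlorophenyl on a saturated ring carbon next to the ring nitrogen (3-chlorophenyl in place of 2-chlorophenyl on a saturated ring carbon) and the rest of the structure is unchanged. Going by the values given here, no measured compound carries 3-chlorophenyl, so the data hold no direct comparison.

Among the compounds with values here, three measured steps bear on the change. Chloro in place of hydrogen gave a 1.1-fold lower number from compound 1 to compound 3 (0.02 log units; within the scatter) and methyl in place of hydrogen gave a 1.2-fold lower number from compound 1 to compound 2 (0.08 log units; within the scatter) while 2-chlorophenyl in place of 3-methylphenyl gave a 1.1-fold higher number from compound 2 to compound 3 (0.06 log units; within the scatter) and all of these lie within the scatter. On that basis, no step beyond the scatter is expected in this assay and neither direction is favoured. The expected step is a 1.1-fold lower number from compound 3 to compound 4 (0.02 log units; within the scatter) and it would stay within the scatter. Compound 4 is estimated at 38000 nM with an expected range from 24000 nM to 58000 nM for its reading.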

Compound 4, half-maximal cytotoxic concentration: 8000 nM
Compound 4: middle estimate off by 4.8-fold (0.68 log units), on the high side; the measured number lies below the stated range.
By their numbers in this assay, from the lowest: compound 4; then compounds 2, 3 and 1 (each within the scatter of the next).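

In this assay, going by these compounds alone, the position on the saturated ring carbon proves sensitive for the first time: with the same atoms joined differently, 3-chlorophenyl in place of 2-chlorophenyl gives a 5.0-fold lower number from compound 3 to compound 4 (0.70 log units; beyond the scatter). The earlier steps shown here at this position had all stayed within the scatter, yet the change is not tied to any group of this pattern, since 3-methylphenyl differs from 3-chlorophenyl only in methyl against chloro and the swap gives a 4.4-fold lower number from compound 2 to compound 4 (0.64 log units; beyond the scatter), while chloro in place of hydrogen on the phenyl of compound 1 gives a 5.3-fold lower number from compound 1 to compound 4 (0.72 log units; beyond the scatter), so less compound is tolerated only when the chlorine sits as it does in 3-chlorophenyl. Nothing in the data accounts for this drop.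

On these data alone, the lower number rests on compound 4 alone, so it remains open whether it belongs to chlorine specifically or would also appear with 3-bromophenyl, 3-methoxyphenyl or 3-trifluoromethylphenyl. As far as these compounds go, it is equally open how 4-chlorophenyl at this position would read, and whether the same swap would matter on a core carrying an amine or a carboxylic acid in place of the sulfonamide.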